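Rhodanine dienes: methyl for trifluoromethyl on the benzyloxy ring

The source may hold more compounds than are shown below. What is called first, only, known or untested is meant among the compounds shown, and "the series" means these compounds.

The series shares a rhodanine core joined through an unsaturated linker to a benzyloxy-substituted aromatic ring. Compound 1 `O=C1NC(=S)S/C1=C\C=C\c1cc(Br)ccc1OCc1ccccc1Br`, compound 2 `O=C1NC(=S)S/C1=C\C=C\c1ccccc1OCc1ccccc1C(F)(F)F` and compound 3 `O=C1NC(=S)S/C1=C\c1cc(Br)ccc1OCc1ccccc1Br` have been run in a functional assay on DLD-1 cells (Homo sapiens), read by microscopy and crystal violet staining, with a stated time of 20 h, tested at 10 ug/mL; on this read-out lower numbers stand for less inhibition and higher numbers for more inhibition at the one concentration tested (going by the name of the read-out). Compound 1 gives 71%, compound 2 gives 80% and compound 3 gives 95%. Compound 2 stands second highest of the three numbers; its gap to compound 1 is within the scatter, and its gap to compound 3 is beyond it. Among the compounds with values here, no two measured compounds differ in one place only, so no single step has yet been isolated.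

Compound 4 `Cc1ccccc1COc1ccccc1/C=C/C=C1\SC(=S)NC1=O` is not yet measured. It differs from compound 2 by methyl in place of trifluoromethyl on an aromatic carbon. Nothing in the measured set speaks to this exchange, so no direction can be drawn from it. The step from compound 2 to compound 4 in this assay is expected to be small, a number 4 percentage points lower from compound 2 to compound 4 (within the scatter), and not beyond the scatter. Compound 4 is estimated at 76%, within a range of 55% to 92%, because compound 2 gives 80% and compound 1 gives 71% with the same linker.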

Compound 4, a percentage reported as inhibition, at one concentration (the size of the read-out at that concentration, not a potency): 73%
Compound 4: the middle estimate sits 3 percentage points above what was measured, and the stated range covers the measured number.
By their numbers in this assay, from the lowest: compounds 1, 4 and 2 (each within the scatter of the next); then compound 3.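

In this assay, within the data shown here, replacing trifluoromethyl with methyl on the aromatic carbon ortho to a large group gives a number 7 percentage points lower from compound 2 to compound 4 (within the scatter), the only single-place step available. This read-out at its one concentration therefore does not separate these two groups at this position, and inhibition persists with either one in place. No measurement shown offers an explanation for this outcome.

Still open, on these data alone, is how a carboxylic acid, an amine or a longer alkyl chain would read at this same aromatic carbon, and whether the hydrogen-bearing parent would fall in the same range. Also open, as far as these compounds go, is whether the methyl and trifluoromethyl groups would remain indistinguishable with bromine on the ring carrying the linker, or at other concentrations.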